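Swapping trifluoromethyl for bromo on compound 2

The source may hold more compounds than are shown below. What is called first, only, known or untested is meant among the compounds shown, and "the series" means these compounds.

Measured in an ADME assay on cells (Homo sapiens) for antiproliferative activity, read by MTT assay; a higher number here means a weaker inhibitor, a lower number a stronger inhibitor:
compound 1 `O=C(NN=C(c1ccccn1)c1ccccn1)c1cccs1`: 950 nM
compound 2 `C/C(=N\NC(=O)c1ccc(C(F)(F)F)cc1)c1cnccn1`: 1160 nM
compound 3 `O=C(NN=C(c1ccccn1)c1ccccn1)c1cccc(Br)c1`: 240 nM

Compound 2 gives 1160 nM, within the scatter of compound 1 at 950 nM, while compound 3 gives the lower 240 nM. Compound 4 `C/C(=N\NC(=O)c1ccc(Br)cc1)c1cnccn1` carries bromo in place of trifluoromethyl on an aromatic carbon. Among the measured compounds shown here, no measured step removes trifluoromethyl. The only one that brings in bromine is a 4.0-fold lower number from compound 1 to compound 3 (0.60 log units; beyond the scatter), a modest step with 3-bromophenyl in place of thiophen-2-yl, and it bears only loosely on this change. In this assay a small move toward a lower number is therefore expected, perhaps none beyond the scatter, and the expected step is a 1.5-fold lower number from compound 2 to compound 4 (0.16 log units; within the scatter). For compound 4 the estimate is 800 nM, with an expected range from 250 nM to 2500 nM.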

Compound 4, half-maximal inhibitory concentration in the Homo sapiens assay: 1220 nM
Estimate against measurement, compound 4: 1.5-fold (0.18 log units) below; the range from low to high includes it.
By their numbers in the Homo sapiens assay, from the lowest: compound 3; then compounds 1, 2 and 4 (each within the scatter of the next).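

In the Homo sapiens assay, a direct exchange of bromo for trifluoromethyl on this aromatic carbon gives a 1.1-fold higher number from compound 2 to compound 4 (0.02 log units; within the scatter), so the two groups cannot be told apart here. Among the compounds shown here, the only earlier step involving bromine also replaced thiophen-2-yl with 3-bromophenyl on another core, whereas this pair isolates the group exchange. The same exchange does separate the compounds in a physicochemical assay for lipophilicity (on this read-out lower numbers stand for lower lipophilicity and higher numbers for higher lipophilicity), where compound 2 gives 2 and compound 4 gives 2.9: the measured partition coefficient of compound 2, 2, and of compound 4, 2.9, a number 0.90 log units higher (beyond the scatter). The compounds shown leave open whether an amine or a carboxylic acid at this place would shift the number in the Homo sapiens assay. They also leave open whether bromo and trifluoromethyl would match on the core of compound 1.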